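This account rests on a few compounds, and the source may have more. Where it says the series, first, only, none or still open, it means among the compounds named here.

Measured so far:
compound 1, `COc1cc(NC(=O)Nc2cc(Nc3ccc(C)c(F)c3)ncn2)cc(OC)c1`, 39.7% in a functional assay on NCI-H226 cells (Homo sapiens) for inhibition, read by MTT assay, with a stated time of 48 h, tested at 10 uM; a higher number here means more inhibition at the concentration tested (going by the name of the read-out), a lower number less inhibition
compound 2, `O=C(Nc1cc(Nc2ccc(F)c(Cl)c2)ncn1)Nc1c(Cl)cccc1Cl`, 47.3%

Two compounds share a urea-linked core and differ in the ring attached to the nitrogen on the aromatic ring. In this assay compound 1 gives 39.7%, and compound 2 gives 47.3%. Compound 1 has the lower of the two numbers, but the gap to compound 2 lies within the usual scatter of repeated measurements, so the two cannot be told apart on these numbers.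

The next compound, compound 3, `COc1cc(NC(=O)Nc2cc(Nc3ccc(OC)c(I)c3)ncn2)cc(OC)c1`, keeps the core of compound 1 and changes one ring: 3-iodo-4-methoxyphenyl in place of 3-fluoro-4-methylphenyl on a nitrogen on an aromatic ring. Among the compounds with values here, no measured pair here shows what such a swap does, so the step is expected to stay within the scatter, in either direction, as a number 2.3 percentage points higher from compound 1 to compound 3 (within the scatter). Compound 3 is therefore expected to give about 42%, between 25% and 60%.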

Compound 3, a percentage reported as inhibition, at one concentration (the size of the read-out at that concentration, not a potency): 40.1%
For compound 3 the middle estimate is 1.9 percentage points above the measured one, within the range that was stated.
By their numbers in this assay, from the lowest: compounds 1, 3 and 2 (each within the scatter of the next).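

Within the data shown here, replacing 3-fluoro-4-methylphenyl with 3-iodo-4-methoxyphenyl on a nitrogen on an aromatic ring gives a number 0.4 percentage points higher from compound 1 to compound 3 (within the scatter) in this assay, the first step here in which only this ring differs. On the core of compound 1, this position therefore takes an iodine and a methoxy group in place of a fluorine and a methyl group with no change that can be told from the scatter. No measurement shown here speaks to why the two numbers lie so close.

The two groups change together, so this step cannot say what iodine or methoxy does alone, and either effect could be hidden by the other. Also open, going by these compounds, is how the number responds when a phenyl ring carrying an amine or a carboxylic acid, or a longer alkyl chain, stands at this position.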